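Swapping a thiazole for a pyridine on an aryl-substituted core

The compounds below may be only part of what the source reports. "The series", "measured", "known", "first", "only" and "open" are said of these compounds alone.

Measured so far:
- compound 1 `c1cc(-c2nccs2)c2c(c1)C(c1ncc[nH]1)CC2`: 3190 nM
- compound 2 `Cc1ccc2c(c1NS(C)(=O)=O)CCC2c1ncc[nH]1`: > 10000 nM
- compound 3 `c1ccc2c(c1)CCCC2c1ncc[nH]1`: 364 nM

In a functional assay on CHO cells for agonist activity at Alpha-1D adrenergic receptor (Homo sapiens), read by FLIPR and calcium flux (a lower number here means that less compound is needed, a higher number that more compound is needed for the effect), compound 1 gives 3190 nM, the highest of the two numbers; compound 3 gives 364 nM, a gap beyond the scatter. Compound 2 gives only a limit of the assay, > 10000 nM, as the limit of > 10000 nM in this assay, at which 1 of the 3 values shown sits, states. Compound 4 `c1cncc(-c2cccc3c2CCC3c2ncc[nH]2)c1` is not yet measured. It differs from compound 1 in one place: pyridin-3-yl in place of 1,3-thiazol-2-yl on an aromatic carbon. For the measured compounds named here, with no measured step of this kind to lean on, the expected step of a 1.5-fold lower number from compound 1 to compound 4 (0.16 log units; within the scatter) is modest, leaning toward a lower number but possibly none beyond the scatter. Compound 4 is estimated at 2200 nM, within 500 nM to 9000 nM.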

Compound 4, half-maximal effective concentration: > 10000 nM
Compound 4 was reported as a limit; the forecaster's own chance of this, stated with the estimate: 15%; at least 4.5-fold (0.65 log units) between middle value and limit.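

For the compounds shown here, this is the first measured step at this position, and it shows that the choice of aromatic ring here matters: pyridin-3-yl in place of 1,3-thiazol-2-yl gives an at least 3.1-fold higher number from compound 1 to compound 4 (0.49 log units; beyond the scatter) in this assay. So one aromatic ring cannot simply stand in for the other on this carbon. The result for compound 4 is a limit of the assay and not a number, which leaves the full size of the step unknown: the limit of > 10000 nM in this assay, at which 2 of the 4 values shown sit.

Still open, on these data alone, is how a non-aromatic group on this carbon, such as an amine or a methoxy group, would compare with 1,3-thiazol-2-yl.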